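The compounds below may be only part of what the source reports. "The series", "measured", "known", "first", "only" and "open" are said of these compounds alone.

Among the compounds with values here, in a functional assay on Caco-2 cells (Homo sapiens) for inhibition, read by MTT assay, with a stated time of 48 h (on this read-out higher numbers stand for weaker inhibition and lower numbers for stronger inhibition), compound 1 (`COc1cc(/C=N/Nc2nc(-c3ccc(Br)cc3)cs2)cc(Br)c1OC`) gives 36200 nM, and this is the only true number so far. Compound 2 (`COc1cc(/C=N/Nc2nc(-c3ccc(Br)cc3)cs2)c(Br)c(Br)c1OC`) reads > 100000 nM and this is a limit of the assay, not a number. Compound 1 can therefore be set only against that limit, not against a second measured value.

Compound 3 (`COc1cc(/C=N/Nc2nc(-c3ccccc3)cs2)cc(Br)c1OC`) is reached from compound 1 by a single change (hydrogen in place of bromo on an aromatic carbon): hydrogen in place of bromo on an aromatic carbon, para to a large group, which turns 4-bromophenyl into phenyl.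

Within the data shown here, only one measured step bears on this, and only loosely: an at least 2.7-fold higher number from compound 1 to compound 2 (0.44 log units; beyond the scatter) is also an exchange between bromo and hydrogen, but it runs the opposite way and sits at another place in the molecule. It gives no firm direction for the 4-bromophenyl group, so no step beyond the usual scatter is expected in this assay, although a move either way remains possible. The expected step is a 1.0-fold lower number from compound 1 to compound 3 (0.01 log units; within the scatter) and it is only an estimate. For compound 3 the estimated value is 35000 nM, with an expected range of 11000 nM to 100000 nM around it.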

Compound 3, half-maximal inhibitory concentration: 64200 nM
For compound 3 the middle estimate is 1.8-fold (0.26 log units) below the measured one; measured number inside the range.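

In this assay, the 4-bromophenyl to phenyl change, made on an aromatic carbon para to a large group, gives a 1.8-fold higher number from compound 1 to compound 3 (0.25 log units; within the scatter). Until now, the only exchange of bromo and hydrogen shown sat at another place in the molecule, and there it gave an at least 2.7-fold higher number from compound 1 to compound 2 (0.44 log units; beyond the scatter). So the two places do not read alike: at this one, the bromo can be lost without a step beyond the scatter, and compound 3 still gives a true number, which shows that this bromo is not needed for a measurable reading in this assay.

Only bromo and hydrogen are shown at this place, so it stays open whether an amine, a carboxylic acid or a longer chain there would leave the number within the scatter or move it clearly in either direction. How much weaker a compound in this series can be also stays open, since the reading for compound 2 is a limit and not a number: the limit of > 100000 nM in this assay, at which 1 of the 3 values shown sits.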